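Replacing a triazolyl group with an imidazolyl group

This account rests on a few compounds, and the source may have more. Where it says the series, first, only, none or still open, it means among the compounds named here.

Going by the values given here, measured in a functional assay on HUVEC cells (Homo sapiens), read by scintillation counting and thymidine incorporation, with a stated time of 24 h (on this read-out lower numbers stand for stronger inhibition and higher numbers for weaker inhibition), compound 1 (`CCC(C)n1ncn(-c2ccc(N3CCN(c4ccc(OC[C@@H]5CO[C@@](CC6CCCC6)(c6ccc(Cl)cc6Cl)O5)cc4)CC3)cc2)c1=O`) gives 512 nM and compound 2 (`CCC(C)n1ncn(-c2ccc(N3CCN(c4ccc(OC[C@@H]5CO[C@@](Cn6nc(C)nc6C)(c6ccc(Cl)cc6Cl)O5)cc4)CC3)cc2)c1=O`) gives 221 nM so compound 2 holds the lower of the two numbers so far. Compound 3 (`CCC(C)n1ncn(-c2ccc(N3CCN(c4ccc(OC[C@@H]5CO[C@@](Cn6c(C)cnc6C)(c6ccc(Cl)cc6Cl)O5)cc4)CC3)cc2)c1=O`) differs from compound 2 in one group: 2,5-dimethyl-1H-imidazol-1-yl stands in place of 3,5-dimethyl-1H-1,2,4-triazol-1-yl on a saturated chain carbon bound to a saturated ring carbon (2,5-dimethyl-1H-imidazol-1-yl in place of 3,5-dimethyl-1H-1,2,4-triazol-1-yl on a saturated chain carbon bound to a saturated ring carbon).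

Among the compounds with values here, only one measured step bears on this place. It is a 2.3-fold lower number from compound 1 to compound 2 (0.36 log units; beyond the scatter) and it came when 3,5-dimethyl-1H-1,2,4-triazol-1-yl took the place of cyclopentyl. That step was modest, though beyond the scatter. The new exchange is narrower on paper, since one five-membered aromatic ring replaces another. Within the data shown here, no measured compound carries the imidazolyl group, so the data give no direction for it. Among the measured compounds shown here, a step in this assay smaller than the one seen with compound 2 is expected, quite possibly none beyond the scatter. The expected change is a 1.1-fold higher number from compound 2 to compound 3 (0.05 log units; within the scatter) as an estimate only. Compound 3 is expected at 250 nM (estimated range 100 nM to 600 nM).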

Compound 3, half-maximal inhibitory concentration: 765 nM
The estimate for compound 3 lay 3.1-fold (0.49 log units) below the measured number; measured number outside the range, above it.
By their numbers in this assay, from the lowest: compound 2; then compounds 1 and 3 (each within the scatter of the next).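

In this assay, the two five-membered aromatic rings are not interchangeable on this saturated chain carbon bound to a saturated ring carbon: exchanging 3,5-dimethyl-1H-1,2,4-triazol-1-yl for 2,5-dimethyl-1H-imidazol-1-yl gives a 3.5-fold higher number from compound 2 to compound 3 (0.54 log units; beyond the scatter) and takes back the gain that the triazolyl group had brought over cyclopentyl. The comparison with the cyclopentyl compound shows a 1.5-fold higher number from compound 1 to compound 3 (0.17 log units; within the scatter) and so leaves the imidazolyl and cyclopentyl groups indistinguishable here, which means that an aromatic ring with two methyl groups at this place does not by itself lower the number. Nothing measured here explains why one ring nitrogen more or less, together with the shifted methyl group, should matter.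

From the compounds shown here alone, the two rings differ both in their hetero atoms and in where a methyl group sits, so it remains open which of these changes counts; the plain 1H-1,2,4-triazol-1-yl and 1H-imidazol-1-yl groups, without methyl groups, would help to separate them. Going by these compounds, how an open-chain amine such as dimethylamino would compare at this place also remains unknown.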